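A few compounds are considered here, and "the series" means these few. Any claim that something is new, unique, unknown or untested is made for them only; others in the source may bear on it.

Compound 1 `C[C@@H](NC(=O)Nc1cccc(Br)c1)c1ccccc1`: 100%
Compound 2 `C[C@@H](NC(=O)Nc1ccc(Br)cc1)c1ccccc1`: 100%
Compound 3 `C[C@@H](NC(=O)Nc1cccc(I)c1)c1ccccc1`: 81%

In an ADME assay on the whole organism with Oryza sativa as the target, tested at 0.1 uM (on this read-out higher numbers stand for a weaker effect at the one concentration tested and lower numbers for a stronger effect), compound 1 and compound 2 stand together at the top of the three numbers, with compound 3 lower. Compound 3 arises from compound 1 by iodo in place of bromo on an aromatic carbon, a step that gave a number 19 percentage points lower from compound 1 to compound 3 (beyond the scatter). Compound 2 is built from the same atoms as compound 1 joined differently; the difference between the two cores is not broken down here. Compound 4 `C[C@@H](NC(=O)Nc1ccc(I)cc1)c1ccccc1` is not yet measured. It arises from compound 2 by iodo in place of bromo on an aromatic carbon. This is the same kind of change as from compound 1 to compound 3, though the place differs: meta to a large group there, para to a large group here. A step of a number 17 percentage points lower from compound 2 to compound 4 (beyond the scatter) is expected in this assay because the same kind of change gave a number 19 percentage points lower from compound 1 to compound 3 (beyond the scatter). Compound 4 is therefore estimated at 83%, likely between 68% and 98%.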

Compound 4, a percentage reported as activity, at one concentration (the size of the read-out at that concentration, not a potency): 100%
For compound 4 the middle estimate is 17 percentage points below the measured one; the whole stated range lies below it.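

Putting iodo in place of bromo gave no change at the digits printed from compound 2 to compound 4 (within the scatter) in this assay. The size of this swap therefore does not carry over from one core to the other in this series: the same change on two cores in this assay, a number 19 percentage points lower (beyond the scatter) from compound 1 to compound 3 and no change at the digits printed (within the scatter) from compound 2 to compound 4, 19 percentage points apart, beyond the scatter of two such steps. This rests on just two steps at a single concentration, so it does not show why the cores respond differently or how the swap would behave on any further core.

The compounds shown leave open how a fluoro, a chloro, a methoxy or a nitrile in the same places would read out. They also leave open whether such groups would track the two halogens shown or follow a course of their own on each core.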